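The compounds below may be only part of what the source reports. "The series", "measured", "known", "first", "only" and "open" are said of these compounds alone.

Compound 1 `CCc1cc(C(C)=O)c(O)cc1OCCCCCCC#N` stands highest of the three measured compounds in an assay on isolated protein for binding affinity to leukotriene B4 receptor 1 (Homo sapiens), tested at 1 uM (a lower number here means less inhibition, a higher number more inhibition at the concentration tested (going by the name of the read-out)), where compound 1 gives 73%. Compound 2 `COCc1cc(C(C)=O)c(O)cc1OCCCCCCC#N` carries methoxy in place of methyl on a saturated chain carbon bound to an aromatic carbon; in this assay compound 2 gives 7%, so that a number 66 percentage points lower from compound 1 to compound 2 (beyond the scatter). Compound 3 `CC(=O)c1cc(CO)c(OCCCCCCC#N)cc1O` carries hydroxy in place of that same methyl; compound 3 gives 8%, so that a number 65 percentage points lower from compound 1 to compound 3 (beyond the scatter). Between the two compounds with the lower numbers, a number 1 percentage points higher from compound 2 to compound 3 (within the scatter).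

Compound 4 `CCc1cc(C(C)=O)c(O)cc1OCCCCCCCC(C)(C)C#N` keeps the core of compound 1 and changes the chain instead: 2-cyano-2-methylpropyl in place of cyano on a saturated chain carbon, six bonds along the chain from an oxygen on an aromatic ring. None of the three measured steps bears on this change; all three alter the group on the saturated chain carbon bound to an aromatic carbon and leave the chain as it is in compound 1. Among the compounds with values here, the two large drops seen in this assay on replacing that methyl therefore give no guide to the chain change, and the data hold no pair of compounds differing at the saturated chain carbon six bonds along the chain from an oxygen on an aromatic ring. Without such a pair, the working expectation is a step of no size beyond the scatter, and compound 4 is estimated at 68%, range 40% to 90%, which would mean an expected a number 5 percentage points lower from compound 1 to compound 4 (within the scatter).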

Compound 4, a percentage reported as inhibition, at one concentration (the size of the read-out at that concentration, not a potency): 29%
Compound 4: middle estimate off by 39 percentage points, on the high side; measured number outside the range, below it.
By their numbers in this assay, from the lowest: compounds 2 and 3 (each within the scatter of the next); then compound 4; then compound 1.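

In this assay, the saturated chain carbon six bonds along the chain from an oxygen on an aromatic ring proves sensitive: with 2-cyano-2-methylpropyl in place of cyano, the result is a number 44 percentage points lower from compound 1 to compound 4 (beyond the scatter). The read-out therefore responds to changes at two separate places on compound 1, this chain carbon and the saturated chain carbon bound to an aromatic carbon, and the step at the chain occurs although the entering group still holds a nitrile, with the same counts of hydrogen-bond donors and acceptors and no net charge. No measurement available here accounts for this step.

The compounds shown do not separate the added chain length from the added branching, and a longer unbranched chain carrying the nitrile, without the methyl groups, would make that distinction. Also open, as far as these compounds go, is how the read-out responds when the nitrile itself gives way to another group, such as a carboxylic acid or an amide, on the chain of compound 1.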